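A few compounds are considered here, and "the series" means these few. Any claim that something is new, unique, unknown or untested is made for them only; others in the source may bear on it.

Measured compounds in a functional assay on the whole organism (strain Swiss) with Mus musculus as the target, in the maximal electroshock model, with a stated time of 0.25 h, at a dose of 100 mg/kg by the intraperitoneal route; on this read-out higher numbers stand for a stronger effect at the one dose given and lower numbers for a weaker effect:
compound 1 `CCC(C(=O)N1CCN(c2cccc(Cl)c2)CC1)N1C(=O)CCC1=O` gives 50%;
compound 2 `COc1cccc(N2CCN(C(=O)C(C)N3C(=O)CCC3=O)CC2)c1` gives 25%;
compound 3 `CCC(C(=O)N1CCN(c2ccccc2)CC1)N1C(=O)CCC1=O` gives 25%.

Compound 2 sits level with compound 3 at the digits given; these two are together the lowest of the three numbers, and compound 1 lies higher than compound 2 by an amount beyond the scatter. Among the measured compounds shown here, no step is tabulated between compound 2 and either compound 1 or compound 3, so only the bare values are set side by side here. For the measured compounds named here, the one tabulated step within the measured set runs a number 25 percentage points lower from compound 1 to compound 3 (beyond the scatter). Going by the values given here, that is so far the only reading of what a substituent on the aromatic ring contributes.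

Compound 4 `CC(C(=O)N1CCN(c2ccccc2F)CC1)N1C(=O)CCC1=O` has yet to be measured. Relative to compound 2 the change is 2-fluorophenyl in place of 3-methoxyphenyl on an amine nitrogen in a ring. The step from compound 1 to compound 3 bears on this only loosely: there a chloro on the aromatic ring was exchanged for hydrogen and the number fell modestly, whereas here a fluorine enters while a methoxy leaves, so two things change at once and the measured step does not map onto it directly. A small rise, or no change beyond the scatter, is therefore expected, and the expected step is a number 10 percentage points higher from compound 2 to compound 4 (within the scatter). On that basis compound 4 is estimated at 35%, with a range from 15% to 55%.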

Compound 4, a percentage reported as activity, at one dose (the size of the read-out at that dose, not a potency): 75%
Estimate against measurement, compound 4: 40 percentage points below; the whole stated range lies below it.
By their numbers in this assay, from the lowest: compounds 2 and 3 (each within the scatter of the next); then compound 1; then compound 4.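

In this assay, a number 50 percentage points higher from compound 2 to compound 4 (beyond the scatter), so the aryl group on this amine nitrogen in a ring can shift the read-out by a large amount with the rest of the molecule unchanged. Among the compounds shown here, the step is rated large, whereas the only earlier single-place step, a number 25 percentage points lower from compound 1 to compound 3 (beyond the scatter), is rated modest, and that earlier step involved only a chloro exchanged for hydrogen on the aromatic ring. Here, however, one exchange alters the substituent and its ring position together, taking 3-methoxyphenyl to 2-fluorophenyl, and nothing shown explains the size of the step.

The compounds shown leave open whether the rise goes with the fluorine or with its ring position, a question that 3-fluorophenyl and 2-methoxyphenyl partners on the core of compound 4 would separate. Also open, on these data alone, is how far the trend extends to other groups on the aromatic ring, such as 2-chlorophenyl or 2-trifluoromethylphenyl, and whether a longer chain in place of the methyl on the core of compound 4 keeps the read-out at this level.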